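This account rests on a few compounds, and the source may have more. Where it says the series, first, only, none or still open, it means among the compounds named here.

Measured compounds:
compound 1 `Cc1ccccc1Nc1nc(NC2CCCCC2)ncc1Cl` — in an ADME assay on L02 cells (Homo sapiens) for inhibition, read by CCK-8 assay, with a stated time of 48 h (on this read-out higher numbers stand for weaker inhibition of growth and lower numbers for stronger inhibition of growth), compound 1 gives > 100000 nM, a limit of the assay rather than a number.
compound 2 `CN1CCN(c2ccc(Nc3ncc(Cl)c(Nc4ccccc4)n3)nc2)CC1` — compound 2 gives 7990 nM.
compound 3 `CN1CCN(c2ccc(Nc3ncc(Cl)c(NCc4ccco4)n3)nc2)CC1` — compound 3 gives 45700 nM.

Among the measured compounds shown here, compound 3 stands at the highest of the two numbers that are known; the nearest is compound 2, and the single step of this kind is a 5.7-fold higher number from compound 2 to compound 3 (0.76 log units; beyond the scatter). Compound 4 `COc1cccc(Nc2nc(Nc3ccc(N4CCN(C)CC4)cn3)ncc2Cl)c1` is not yet measured. It differs from compound 3 in one place: 3-methoxyphenyl in place of (furan-2-yl)methyl on a nitrogen on an aromatic ring. For the measured compounds named here, the change carries the same nitrogen back from a (furan-2-yl)methyl to an aromatic ring of carbon only, which is the reverse of the only measured step, so that step is the one that bears on it, and a step of roughly its size in the opposite direction is expected, giving a lower number than compound 3. The 3-methoxyphenyl is not identical to the phenyl of compound 2, so some room is left on either side. Compound 4 is therefore expected to show a 4.6-fold lower number from compound 3 to compound 4 (0.66 log units; beyond the scatter). The estimate for compound 4 is 10000 nM, ranging from 3500 nM to 30000 nM.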

Compound 4, concentration for 50% growth inhibition: 3470 nM
Compound 4: the middle estimate sits 2.9-fold (0.46 log units) above what was measured; the measured number lies below the stated range.
By their numbers in this assay, from the lowest: compound 4; then compound 2; then compound 3. At a limit, above all of these: compound 1.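

On this nitrogen, this assay shows that an aromatic ring of carbon only again goes with the lower number, and that this holds for a substituted ring as well as for phenyl: a 13-fold lower number from compound 3 to compound 4 (1.12 log units; beyond the scatter). The ring itself also proves open to change, as methoxy in place of hydrogen on an aromatic carbon gives a 2.3-fold lower number from compound 2 to compound 4 (0.36 log units; beyond the scatter), a modest step but beyond the scatter, so the number at this nitrogen depends on more than the choice between the two ring types. Nothing shown here accounts for either step.

The compounds shown leave open whether methoxy is special or whether other groups on this ring, such as a fluorine, an amine or a carboxylic acid, would shift the number in the same direction. They also leave open how a longer chain carrying the 3-methoxyphenyl on this nitrogen would read.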